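Sulfonylurea aorta series: chloro to fluoro on the aryl ring

The source may hold more compounds than are shown below. What is called first, only, known or untested is meant among the compounds shown, and "the series" means these compounds.

Measured compounds:
compound 1 `COc1ccc(F)cc1C(C)NC(=O)N(C)S(=O)(=O)c1ccc(C)cc1` in a functional assay on thoracic aorta (Rattus norvegicus, strain Wistar), with a stated time of 15 min (a higher number here means that more compound is needed for the effect, a lower number that less compound is needed), gives 11700 nM
compound 2 `CCOc1ccc(F)cc1C(C)NC(=O)NS(=O)(=O)c1ccc(C)cc1` in this assay gives > 300000 nM, a limit of the assay
compound 3 `COc1ccc(Cl)cc1C(C)NC(=O)NS(=O)(=O)c1ccc(C)cc1` in this assay gives > 300000 nM, a limit of the assay

Compound 3 therefore stands at the top of what this assay reports, with no number of its own; the limit of > 300000 nM in this assay, at which 2 of the 3 values shown sit, describes where it and one other compound sit. Compound 4 `COc1ccc(F)cc1C(C)NC(=O)NS(=O)(=O)c1ccc(C)cc1` is not yet measured. It differs from compound 3 in one place: fluoro in place of chloro on an aromatic carbon. Among the measured compounds shown here, no pair of measured compounds shows this change, so its size in this assay is unknown. For the measured compounds named here, the one numbered value, from compound 1, shows that this scaffold can give a measurable concentration.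

Compound 4 is estimated at 80000 nM, in a range from 8000 nM to 300000 nM. The implied step an at least 3.7-fold lower number from compound 3 to compound 4 (0.57 log units; beyond the scatter) is expected to move toward less compound being needed, though a limit remains quite possible.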

Compound 4, half-maximal effective concentration: > 300000 nM
Compound 4 gave a limit, no number; the forecaster's own chance of this, stated with the estimate: 45%; at least 3.7-fold (0.57 log units) between middle value and limit.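

With fluoro in place of chloro, para to a methoxy group, compound 4 also sits at a limit in this assay, so neither halogen gives a number here: the limit of > 300000 nM in this assay, at which 3 of the 4 values shown sit.

The steps to compound 4 from compound 3 and from compound 2 cannot be read, as both ends are limits. Hydrogen in place of methyl on the amide-type nitrogen gives an at least 25-fold higher number from compound 1 to compound 4 (1.40 log units; beyond the scatter), so the only numbered value goes with that methyl, not with the halogen.

Open, on these data alone, is whether chloro and fluoro differ once that nitrogen carries methyl. Also open, as far as these compounds go, is whether an ethyl or a longer chain on that nitrogen keeps a measurable value.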